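The source may report more compounds than this note shows. Statements on the series, on what has been measured and on what is new or still open speak of the compounds shown alone.

Measured compounds:
- Compound 1, `CCCc1nc(-c2ccccc2)c(CNCCN2CCN(c3ccc(F)cc3)CC2)o1`: 54.1%
- Compound 2, `CCCc1nc(-c2ccccc2)c(CNCCN2CCN(c3ccc(C)cc3)CC2)o1`: 48.1%

In an assay on HEK293 cells for inhibition of Voltage-dependent T-type calcium channel subunit alpha-1G (Homo sapiens), read by fluorescence, tested at 10 uM (a lower number here means less inhibition, a higher number more inhibition at the concentration tested (going by the name of the read-out)), compound 1 gives 54.1% and compound 2 gives 48.1%. Of the two numbers shown, the one for compound 2 is the lower, its only neighbour being compound 1, yet the step of a number 6 percentage points lower from compound 1 to compound 2 (within the scatter) is within the usual scatter, so the two cannot be told apart on these data.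

Compound 3, `CCCc1nc(-c2ccccc2)c(CNCCN2CCN(c3ccccc3C)CC2)o1`, differs from compound 2 in one place: 2-methylphenyl in place of 4-methylphenyl on an amine nitrogen in a ring. The 2-methylphenyl and the 4-methylphenyl contain the same atoms joined differently, so nothing is added or removed; only the place of the methyl on the phenyl changes.

Among the compounds with values here, the single measured step, from compound 1 to compound 2, exchanged one small group for another at the same place and came out within the scatter. Within the data shown here, no measured step moves a group around the phenyl, so none bears directly on this change. With nothing pointing in either direction, the expected step is a number 3.1 percentage points lower from compound 2 to compound 3 (within the scatter), that is, none beyond the scatter.

Compound 3 is therefore estimated at 45%, in the range 25% to 65%.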

Compound 3, a percentage reported as inhibition, at one concentration (the size of the read-out at that concentration, not a potency): 51.3%
For compound 3 the middle estimate is 6.3 percentage points below the measured one; the measured number falls inside the stated range.
By their numbers in this assay, from the lowest: compounds 2, 3 and 1 (each within the scatter of the next).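

Moving the methyl around the phenyl, with 2-methylphenyl in place of 4-methylphenyl on the amine nitrogen in the ring, gives in this assay a step of a number 3.2 percentage points higher from compound 2 to compound 3 (within the scatter) and so does not separate the two isomers, even though this change adds and removes no atoms. The comparison with the fluorinated compound points the same way, with a number 2.8 percentage points lower from compound 1 to compound 3 (within the scatter) for 2-methylphenyl in place of 4-fluorophenyl, so all three groups tried at this place give numbers that cannot be told apart, and no compound shown goes against that. With so little spread, and with nothing measured that could account for it, no explanation for these numbers can be offered here.

Still open, as far as these compounds go, is whether a more different group on this phenyl, such as a carboxylic acid or an amine in place of the methyl, would shift the inhibition beyond the usual scatter. Also open is how the number would respond to a change elsewhere in the shared core, such as a longer chain, since every compound shown carries the same core and differs only in the group on the ring nitrogen.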